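This account rests on a few compounds, and the source may have more. Where it says the series, first, only, none or still open, it means among the compounds named here.

Compound 1 `CCCCC#Cc1cc([C@@H]2O[C@H](CO)[C@@H](O)[C@H]2O)n2ncnc(N)c12` gives 200 nM in a functional assay on Z-138 cells (Homo sapiens) for antiproliferative activity, with a stated time of 72 h; a lower number here means a stronger inhibitor, a higher number a weaker inhibitor.
Compound 2 `Nc1ncnn2c([C@@H]3O[C@H](CO)[C@@H](O)[C@H]3O)cc(C#Cc3ccccc3)c12` gives 41400 nM.
Compound 3 `Nc1ncnn2c([C@@H]3O[C@H](CO)[C@@H](O)[C@H]3O)cc(-c3ccccc3F)c12` gives 95300 nM.

Among these three numbers compound 2 stands second highest: its nearest neighbour is compound 3, reached by a 2.3-fold higher number from compound 2 to compound 3 (0.36 log units; beyond the scatter), and its furthest is compound 1, since a 210-fold higher number from compound 1 to compound 2 (2.32 log units; beyond the scatter). Compound 4 `COc1ccc(-c2cc([C@@H]3O[C@H](CO)[C@@H](O)[C@H]3O)n3ncnc(N)c23)cc1` has not yet been measured. It differs from compound 2 in one place: 4-methoxyphenyl in place of 2-phenylethynyl on an aromatic carbon. The measured step that bears most on this change is the one where 2-fluorophenyl replaced 2-phenylethynyl on the same aromatic carbon, giving a 2.3-fold higher number from compound 2 to compound 3 (0.36 log units; beyond the scatter), a modest weakening. The step of a 480-fold higher number from compound 1 to compound 3 (2.68 log units; beyond the scatter) shows that a directly attached ring is also far weaker than hex-1-yn-1-yl there. Whether the 4-methoxyphenyl group behaves differently from 2-fluorophenyl cannot be told from these three compounds. For compound 4 a modest weakening, or no change beyond the scatter, is therefore expected, as a 1.9-fold higher number from compound 2 to compound 4 (0.29 log units; within the scatter). The estimate for compound 4 is 80000 nM, within 20000 nM to 300000 nM.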

Compound 4, half-maximal inhibitory concentration: 62600 nM
The estimate for compound 4 lay 1.3-fold (0.11 log units) above the measured number; the measured number falls inside the stated range.
By their numbers in this assay, from the lowest: compound 1; then compounds 2, 4 and 3 (each within the scatter of the next, the first and the last beyond it).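

In this assay, on the aromatic carbon two ring bonds from the ring nitrogen, placing 4-methoxyphenyl instead of 2-phenylethynyl gives a 1.5-fold higher number from compound 2 to compound 4 (0.18 log units; within the scatter), and placing it instead of 2-fluorophenyl gives a 1.5-fold lower number from compound 3 to compound 4 (0.18 log units; within the scatter). These three ring-bearing groups therefore cannot be told apart here, even though 4-methoxyphenyl brings a hydrogen-bond acceptor and has no triple bond. Compound 4 also joins the other two in lying far from the hex-1-yn-1-yl compound, with a 310-fold higher number from compound 1 to compound 4 (2.50 log units; beyond the scatter), so compound 1 is the only one of the four with a low number, and no compound shown goes against this.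

Nothing available explains the gap between the chain and the ring-bearing groups. On these data alone, whether the chain's length or its triple bond matters stays open, and a saturated hexyl chain or a shorter propynyl chain on this carbon could separate the two.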